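This account rests on a few compounds, and the source may have more. Where it says the series, first, only, none or still open, it means among the compounds named here.

Measured so far:
compound 1 `FC(F)(F)c1ccccc1-c1nc(NCc2ccc(-c3cncnc3)cc2)c2ccccc2n1`: 3000 nM
compound 2 `CCc1ccccc1-c1nc(NCc2ccc(-c3cccnc3)cc2)c2ccccc2n1`: 780 nM

In an assay on a protein complex for inhibition of ubiquitin carboxyl-terminal hydrolase 1/WD repeat-containing protein 48 (Homo sapiens), read by fluorescence (on this read-out lower numbers stand for stronger inhibition and higher numbers for weaker inhibition), compound 2 gives 780 nM, the lowest of the two numbers. Compound 1 gives 3000 nM in this assay, a higher number, and the gap between the two lies beyond the scatter. Compound 3 `c1cncc(-c2ccc(CNc3nc(N4CCCC4)nc4ccccc34)cc2)c1` has not yet been measured in this assay. Its change from compound 2: pyrrolidin-1-yl in place of 2-ethylphenyl on an aromatic carbon. Within the data shown here, neither measured compound tests an exchange of this kind, since both carry a six-membered aromatic ring of carbon only at this place; the series gives no step from which to read the effect. The expectation is a move toward a higher number, beyond the scatter, as a 3.8-fold higher number from compound 2 to compound 3 (0.59 log units; beyond the scatter), with wide uncertainty. For compound 3 in this assay the estimate is 3000 nM, with a range from 800 nM to 12000 nM.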

Compound 3, half-maximal inhibitory concentration: "not active" (no number reported)
Compound 3: no number reported, and the estimate cannot be compared.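

Among these compounds, compound 3 is reported as "not active" without a number, so no step from compound 2 to compound 3 can be read. The compounds shown leave open how far pyrrolidin-1-yl in place of 2-ethylphenyl shifts inhibition. No supporting evidence bears on this result.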